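Aryl swap at the alkyne: from compound 3 to compound 4

The source may hold more compounds than are shown below. What is called first, only, known or untested is meant among the compounds shown, and "the series" means these compounds.

Compound 3 `C#Cc1ccnc(C#Cc2ccc3ncn(-c4ccnc(N)n4)c3c2)c1` gives 316 nM in an assay on Sf9 cells for inhibition of mitogen-activated protein kinase kinase kinase 14 variant S549D (Homo sapiens), with a stated time of 30 min, in the presence of a further agent that is not named here (on this read-out lower numbers stand for stronger inhibition and higher numbers for weaker inhibition), the lowest of the three measured numbers. Compound 1 `C#Cc1cc(C#Cc2ccc3ncn(-c4ccnc(N)n4)c3c2)ccn1` gives 31600 nM and compound 2 `C#Cc1cncc(C#Cc2ccc3ncn(-c4ccnc(N)n4)c3c2)c1` gives 63100 nM in this assay; the steps of a 100-fold lower number from compound 1 to compound 3 (2.00 log units; beyond the scatter) and a 200-fold lower number from compound 2 to compound 3 (2.30 log units; beyond the scatter) show that the group on the triple-bonded carbon moves the read-out strongly, whereas a 2.0-fold higher number from compound 1 to compound 2 (0.30 log units; within the scatter) does not. Compound 4 `C=Cc1nccc(C#Cc2ccc3ncn(-c4ccnc(N)n4)c3c2)n1` carries a group of 8 heavy atoms (6 carbon, 2 nitrogen; one six-membered aromatic ring with 2 hetero atoms) in place of a group of 8 heavy atoms (7 carbon, 1 nitrogen; one six-membered aromatic ring with 1 hetero atom), on a triple-bonded carbon. The measured steps bear on this position only through ring swaps of the same size, so a large move in either direction is possible; the expected outcome is a moderate loss, a 3.2-fold higher number from compound 3 to compound 4 (0.50 log units; beyond the scatter). For compound 4 the estimate in this assay is 1000 nM, within 150 nM to 8000 nM.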

Compound 4, half-maximal inhibitory concentration: 39800 nM
For compound 4 the middle estimate is 40-fold (1.60 log units) below the measured one; measured number outside the range, above it.
By their numbers in this assay, from the lowest: compound 3; then compounds 1, 4 and 2 (each within the scatter of the next).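

The 4-ethynylpyridin-2-yl group of compound 3 is not interchangeable with this ring of the same size: a 130-fold higher number from compound 3 to compound 4 (2.10 log units; beyond the scatter). Compound 4 falls level with the other two ring swaps, with a 1.6-fold lower number from compound 2 to compound 4 (0.20 log units; within the scatter) and a 1.3-fold higher number from compound 1 to compound 4 (0.10 log units; within the scatter), so among these four only compound 3 stands apart at this position. No measurement shown accounts for this loss.

The step changes the ring's hetero atoms and replaces a triple bond outside the ring with a double bond, and these two changes cannot be separated here. As far as these compounds go, it also remains open how an amine or a methyl group in place of the ethynyl group on the ring of compound 3 would read.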